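This account rests on a few compounds, and the source may have more. Where it says the series, first, only, none or still open, it means among the compounds named here.

Three compounds built on one shared core have been examined in a functional assay on A549 cells (Homo sapiens) for antiproliferative activity, read by MTT assay, with a stated time of 24 h; a lower number here means a stronger inhibitor, a higher number a weaker inhibitor. Compound 1 `O=c1[nH]cc(S(=O)(=O)Nc2ccccc2-c2cn(-c3cccc(F)c3)nn2)c(=O)[nH]1` gives 8130 nM in this assay. Compound 2 `O=c1[nH]cc(S(=O)(=O)Nc2cccc(-c3cn(-c4cccc(Cl)c4)nn3)c2)c(=O)[nH]1` gives 2430 nM in this assay. Compound 3 `O=c1[nH]cc(S(=O)(=O)Nc2ccc(-c3cn(-c4ccccc4)nn3)cc2)c(=O)[nH]1` gives 7170 nM in this assay. Among these three numbers compound 3 stands second highest. Its nearest neighbour is compound 1, whose number lies within the usual scatter, so no order between the two can be read. Compound 2 shows a lower number, and that gap lies beyond the scatter.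

Compound 4 `Cc1ccccc1-n1cc(-c2ccc(NS(=O)(=O)c3c[nH]c(=O)[nH]c3=O)cc2)nn1` has not yet been measured in this assay. It differs from compound 3 by methyl in place of hydrogen on an aromatic carbon, ortho to a large group, so that phenyl becomes 2-methylphenyl. Among the measured compounds shown here, no pair of measured compounds differs in a single place, so no measured step is available for this kind of change. A step of modest size, a 1.2-fold lower number from compound 3 to compound 4 (0.08 log units; within the scatter), is expected, with no direction that can be called beyond the scatter. Compound 4 is estimated at 6000 nM, within a range from 2500 nM to 15000 nM.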

Compound 4, half-maximal inhibitory concentration: 3130 nM
Compound 4: the middle estimate sits 1.9-fold (0.28 log units) above what was measured; measured number inside the range.
By their numbers in this assay, from the lowest: compounds 2 and 4 (each within the scatter of the next); then compounds 3 and 1 (each within the scatter of the next).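

In this assay, methyl in place of hydrogen on an aromatic carbon, ortho to a large group, turns phenyl into 2-methylphenyl and gives a 2.3-fold lower number from compound 3 to compound 4 (0.36 log units; beyond the scatter). Among the compounds shown here, this is the first step that changes a single place, and it shows that the number responds to this position, even to an entering group of one carbon. Nothing measured here bears on why the number moves with this change.

From the compounds shown here alone, what an ethyl group, a methoxy group, a chlorine atom or an amine would do on this same carbon remains open. Going by these compounds, it is also open whether methyl would give a step of similar size on the frameworks of compound 1 and compound 2.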